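A few compounds are considered here, and "the series" means these few. Any claim that something is new, unique, unknown or untested is made for them only; others in the source may bear on it.

Values in a physicochemical assay for solubility, in phosphate buffer, at pH 7.4 (on this read-out lower numbers stand for lower solubility and higher numbers for higher solubility), so far:
compound 1 `CC(=O)N[C@@H]1CCC[C@H](C(=O)Nc2cc(-c3cnn4c3CCCC4)c(Cl)cn2)C1` gives 310000 nM
compound 2 `CC(=O)N[C@@H]1CCC[C@H](C(=O)Nc2cc(-c3cnn4ccccc34)c(Cl)cn2)C1` gives 45000 nM
compound 3 `CC(=O)N[C@@H]1CCC[C@H](C(=O)Nc2cc(-c3cnn4c3OCCC4)c(Cl)cn2)C1` gives 110000 nM

Compound 3 stands second highest of the three, with compound 1 at 310000 nM and compound 2 at 45000 nM. The next entry, compound 4 `CC(=O)N[C@@H]1CCC[C@H](C(=O)Nc2cc(-c3cnn4c3CC(C)(C)C4)c(Cl)cn2)C1`, differs from compound 3 in one group (a group of 10 heavy atoms (8 carbon, 2 nitrogen; one five-membered non-aromatic ring with 1 hetero atom, one five-membered aromatic ring with 2 hetero atoms) in place of a group of 9 heavy atoms (6 carbon, 2 nitrogen, 1 oxygen; one five-membered aromatic ring with 2 hetero atoms, one six-membered non-aromatic ring with 2 hetero atoms), on an aromatic carbon), which sits ortho to a chloro group.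

Three measured steps exchange a group at this same place, and all are modest: a 6.9-fold lower number from compound 1 to compound 2 (0.84 log units; beyond the scatter), a 2.8-fold lower number from compound 1 to compound 3 (0.45 log units; beyond the scatter) and a 2.4-fold higher number from compound 2 to compound 3 (0.39 log units; beyond the scatter). The nearest guide is compound 1, which, like compound 4, has a non-aromatic ring with 1 hetero atom and no oxygen in the group. Its step to compound 3 (a 2.8-fold lower number from compound 1 to compound 3 (0.45 log units; beyond the scatter)) suggests that removing the oxygen could lean upward. However, no measured compound carries the five-membered non-aromatic ring, so this guide is weak.

The expected change in this assay is therefore none beyond the scatter, with an estimated 1.5-fold higher number from compound 3 to compound 4 (0.16 log units; within the scatter) as the working figure. For compound 4 the estimate is 160000 nM, with an expected range from 60000 nM to 350000 nM.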

Compound 4, solubility: 150000 nM
Compound 4: the middle estimate sits 1.1-fold (0.03 log units) above what was measured, within the range that was stated.
By their numbers in this assay, from the lowest: compound 2; then compounds 3 and 4 (each within the scatter of the next); then compound 1.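

In this assay, the group with a five-membered non-aromatic ring with 1 hetero atom, ortho to a chloro group, reads level with the oxygen-containing group it replaces (a 1.4-fold higher number from compound 3 to compound 4 (0.13 log units; within the scatter)), so this exchange of ring size and hetero atoms brings no change beyond the scatter. The other two steps do lie beyond the scatter: a 3.3-fold higher number from compound 2 to compound 4 (0.52 log units; beyond the scatter) extends the earlier finding that compound 2, with its six-membered aromatic ring, gives the lowest number of the set, while a 2.1-fold lower number from compound 1 to compound 4 (0.32 log units; beyond the scatter) shows that a non-aromatic ring with 1 hetero atom and no oxygen does not by itself carry the number of compound 1. Nothing available explains any of these differences.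

The compounds shown leave open what the methyl groups of compound 4 contribute apart from the ring size, and whether an amine or a carboxylic acid on the non-aromatic ring would move the number beyond the scatter. From the compounds shown here alone, how these groups would behave with a nitrile in place of the chloro group also remains open.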